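The source may hold more compounds than are shown below. What is called first, only, known or untested is meant among the compounds shown, and "the series" means these compounds.

Of the compounds shown here, three sharing one core have so far been measured in a functional assay on ME-180 cells (Homo sapiens) for cytotoxicity, read by MTT assay, with a stated time of 72 h; on this read-out higher numbers stand for weaker inhibition and lower numbers for stronger inhibition. Compound 1 `COc1cccc(/C=C/C(=O)Nc2cc(C(=O)c3cc(OC)c(OC)c(OC)c3)ccc2OC)c1` gives 4300 nM, compound 2 `C#CCOc1cccc(/C=C/C(=O)Nc2cc(C(=O)c3cc(OC)c(OC)c(OC)c3)ccc2OC)c1` gives 15300 nM, and compound 3 `COc1ccc(C(=O)c2cc(OC)c(OC)c(OC)c2)cc1NC(=O)/C=C/c1ccc(F)cc1` gives 300 nM, the lowest of the three numbers. Its nearest neighbour is compound 1, with a 14-fold lower number from compound 1 to compound 3 (1.16 log units; beyond the scatter), and the furthest is compound 2, with a 51-fold lower number from compound 2 to compound 3 (1.71 log units; beyond the scatter). Compound 4 `COc1ccc(C(=O)c2cc(OC)c(OC)c(OC)c2)cc1NC(=O)/C=C/c1cccc(OC(F)(F)F)c1` carries 3-(trifluoromethoxy)phenyl in place of 4-fluorophenyl on a double-bonded chain carbon bound to a double-bonded chain carbon. Within the data shown here, two measured steps bear directly on this change: both steps ending at compound 3 brought in the same 4-fluorophenyl in place of a phenyl carrying another substituent, and the numbers fell sharply, as a 14-fold lower number from compound 1 to compound 3 (1.16 log units; beyond the scatter) and a 51-fold lower number from compound 2 to compound 3 (1.71 log units; beyond the scatter) show; compound 4 runs in the opposite direction. The step of a 3.6-fold higher number from compound 1 to compound 2 (0.55 log units; beyond the scatter) also shows a higher number when the substituent on that phenyl was varied. A clearly higher number than compound 3 is therefore expected for compound 4, estimated as a 10-fold higher number from compound 3 to compound 4 (1.00 log units; beyond the scatter), because of a 14-fold lower number from compound 1 to compound 3 (1.16 log units; beyond the scatter) in the reverse sense. Compound 4 is estimated at 3000 nM, in a range from 800 nM to 12000 nM.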

Compound 4, half-maximal inhibitory concentration: 9200 nM
Estimate against measurement, compound 4: 3.1-fold (0.49 log units) below; the range from low to high includes it.
By their numbers in this assay, from the lowest: compound 3; then compound 1; then compounds 4 and 2 (each within the scatter of the next).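

In this assay the change at this position gives a 31-fold higher number from compound 3 to compound 4 (1.49 log units; beyond the scatter) and places 3-(trifluoromethoxy)phenyl with the other two oxygen-bearing phenyl groups, well above compound 3, which stays alone at the low end. Trifluoromethyl in place of methyl on that oxygen gives only a 2.1-fold higher number from compound 1 to compound 4 (0.33 log units; beyond the scatter) and is a much smaller step than the one away from 4-fluorophenyl. Trifluoromethyl in place of propargyl gives a 1.7-fold lower number from compound 2 to compound 4 (0.22 log units; within the scatter) so those two compounds cannot be told apart, and fluorine on that oxygen does not bring back the low number of compound 3.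

The compounds shown leave open whether that low number goes with the fluorine itself or with where it stands on the phenyl, and what a chlorine, an amine or a bare phenyl would give here. Nothing measured here accounts for these differences.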